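Trifluoromethoxy in place of trifluoromethyl on a shared core

The source may report more compounds than this note shows. Statements on the series, on what has been measured and on what is new or still open speak of the compounds shown alone.

Compound 1 `Oc1ccc(-c2cc(-c3cccc(F)c3)cc(-c3cccc(O)c3)n2)cc1`: in a functional assay on T47D cells (Homo sapiens) for inhibition (on this read-out lower numbers stand for stronger inhibition and higher numbers for weaker inhibition), compound 1 gives 3510 nM
Compound 2 `Oc1ccc(-c2cc(-c3ccc(C(F)(F)F)cc3)cc(-c3cccc(O)c3)n2)cc1`: in this assay compound 2 gives 2870 nM
Compound 3 `Oc1ccc(-c2cc(-c3ccc(C(F)(F)F)cc3)cc(-c3ccc(O)cc3)n2)cc1`: in this assay compound 3 gives > 50000 nM, which is a limit of the assay rather than a number

Of the two numbers shown, those of compound 2 and compound 1 lie within the usual scatter of each other, so neither can be called stronger. The value of compound 3 is only a limit (the limit of > 50000 nM in this assay, at which 1 of the 3 values shown sits).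

Compound 4 `Oc1ccc(-c2cc(-c3ccc(OC(F)(F)F)cc3)cc(-c3cccc(O)c3)n2)cc1` differs from compound 2 in a single place: trifluoromethoxy in place of trifluoromethyl on an aromatic carbon. Going by the values given here, no measured step changes exactly this group, so the expectation rests on neighbouring changes. The step of a 1.2-fold lower number from compound 1 to compound 2 (0.09 log units; within the scatter) changed the substituent on the same ring and hardly moved the number. The step of an at least 17-fold higher number from compound 2 to compound 3 (1.24 log units; beyond the scatter) was large, but it moved a hydroxy group on a different ring and does not speak to the change made here. A step of a 1.0-fold higher number from compound 2 to compound 4 (0.02 log units; within the scatter) is therefore expected, within the scatter. Compound 4 is expected to give 3000 nM, in a range from 1200 nM to 8000 nM.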

Compound 4, half-maximal inhibitory concentration: 18900 nM
The estimate for compound 4 lay 6.3-fold (0.80 log units) below the measured number; measured number above the stated range.
By their numbers in this assay, from the lowest: compounds 2 and 1 (each within the scatter of the next); then compound 4. At a limit, above all of these: compound 3.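

The ring carrying this substituent turns out not to be indifferent to change. The earlier swap on it, a 1.2-fold lower number from compound 1 to compound 2 (0.09 log units; within the scatter), suggested that the number might not depend much on this group, yet in this assay the new step, a 6.6-fold higher number from compound 2 to compound 4 (0.82 log units; beyond the scatter), shows weaker inhibition once trifluoromethoxy, with its oxygen atom and hydrogen-bond acceptor, replaces trifluoromethyl at the same place. No measurement shown here explains why this small exchange matters.

With only three different groups shown on this ring, no trend in its substituents can be drawn. Going by these compounds, it remains open whether a methoxy group, a nitrile, an amine or a carboxylic acid at this place would behave like trifluoromethyl or like trifluoromethoxy.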